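Shifting the Hydroxy Group to the Other Ring Position

The compounds below may be only part of what the source reports. "The series", "measured", "known", "first", "only" and "open" are said of these compounds alone.

Of the compounds shown here, three sharing one core have been tested in a functional assay on A549 cells (Homo sapiens) for inhibition, read by MTT assay, with a stated time of 24 h; a higher number here means a weaker inhibitor, a lower number a stronger inhibitor. Compound 1 `CC1(C)[C@H]2CC[C@]1(C)N(Cc1cn(-c3cccc(F)c3)nn1)C(=O)C2` gives 180 nM, compound 2 `CC1(C)[C@H]2CC[C@]1(C)N(Cc1cn(-c3ccccc3F)nn1)C(=O)C2` gives 240 nM, and compound 3 `CC1(C)[C@H]2CC[C@]1(C)N(Cc1cn(-c3ccccc3O)nn1)C(=O)C2` gives 230 nM. Compound 2 sits within the scatter of both neighbours: the step of a 1.3-fold higher number from compound 1 to compound 2 (0.12 log units; within the scatter) and the step of a 1.0-fold lower number from compound 2 to compound 3 (0.02 log units; within the scatter) are each too small to count as a real change, as is the step of a 1.3-fold higher number from compound 1 to compound 3 (0.11 log units; within the scatter).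

The next compound, compound 4 `CC1(C)[C@H]2CC[C@]1(C)N(Cc1cn(-c3cccc(O)c3)nn1)C(=O)C2`, differs from compound 2 as follows: 3-hydroxyphenyl in place of 2-fluorophenyl on an aromatic nitrogen. Going by the values given here, two measured steps bear on this change. Moving a fluorine from one ring position to the other, seen from compound 1 to compound 2, left the number within the scatter. Swapping fluoro for hydroxy at the same ring position, seen from compound 2 to compound 3, also left the number within the scatter. Combining both small moves gives no reason to expect a step beyond the scatter in this assay. Compound 4 is therefore estimated at 200 nM, with a likely range from 100 nM to 400 nM. The expected step is a 1.2-fold lower number from compound 2 to compound 4 (0.08 log units; within the scatter), essentially flat.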

Compound 4, half-maximal inhibitory concentration: 180 nM
For compound 4 the middle estimate is 1.1-fold (0.05 log units) above the measured one; the range from low to high includes it.
By their numbers in this assay, from the lowest: compounds 1, 4, 3 and 2 (each within the scatter of the next).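

In this assay, compound 4 completes a set of four in which fluoro or hydroxy sits at either of two ring positions, and the new steps to the two 2-substituted compounds stay small: a 1.3-fold lower number from compound 2 to compound 4 (0.12 log units; within the scatter) changes both the group and its position at once, yet it does not leave the scatter. Moving the hydroxy group alone gives a 1.3-fold lower number from compound 3 to compound 4 (0.11 log units; within the scatter), so a shift of position that had so far been seen only for fluorine now looks just as small for hydroxy. The swap of fluoro for hydroxy can also now be read a second time, as no change at the digits printed from compound 1 to compound 4 (within the scatter), and the two readings agree, so on this phenyl ring the swap makes no measurable difference at either position: the same change on two cores in this assay, a 1.0-fold lower number (0.02 log units; within the scatter) from compound 2 to compound 3 and no change at the digits printed (within the scatter) from compound 1 to compound 4, 1.0-fold (0.02 log units) apart, within the scatter of two such steps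

On these data alone, all four compounds carry one small group on the phenyl ring, so it remains open whether an amine, a carboxylic acid or a longer chain such as butoxy at these positions would move the number beyond the scatter. As far as these compounds go, it is also open how a plain phenyl ring with no added group would compare in this assay.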